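The compounds below may be only part of what the source reports. "The series", "measured", "known", "first", "only" and "open" are said of these compounds alone.

Among the compounds with values here, compound 1 `COc1cc2ncnc(NNC(=S)NC(=O)c3ccccc3Cl)c2cc1OC` is the weaker of the two measured members: in a functional assay on MGC-803 cells (Homo sapiens) for cytotoxicity, read by MTT assay, with a stated time of 72 h (on this read-out lower numbers stand for stronger inhibition and higher numbers for weaker inhibition), compound 1 gives 6440 nM, the highest of the two numbers so far. Compound 2 `COc1cc2ncnc(NNC(=S)NC(=O)c3ccc(Cl)cc3)c2cc1OC` is its nearest neighbour; in this assay compound 2 gives 3710 nM. Within the data shown here, the only measured step, a 1.7-fold lower number from compound 1 to compound 2 (0.24 log units; within the scatter), lies within the scatter, so the two numbers cannot be ordered.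

Compound 3 `COc1cc2ncnc(NNC(=S)NC(=O)c3ccc(F)cc3)c2cc1OC` is the next member to be read. Against compound 1 the change is 4-fluorophenyl in place of 2-chlorophenyl on a carbonyl carbon. Among the measured compounds shown here, only the step from compound 1 to compound 2 bears on this, since it also moves the substituent from the 2-chlorophenyl arrangement to the 4-position pattern on the same carbonyl carbon, and it stayed within the scatter. For the measured compounds named here, no measured pair exchanges chlorine for fluorine, so that part of the change is not covered by any number.

The expectation for compound 3 is therefore a step no larger than the scatter, a 1.4-fold lower number from compound 1 to compound 3 (0.16 log units; within the scatter), leaning if anything toward a slightly lower number. The estimate for compound 3 in this assay is 4500 nM, with a range from 1800 nM to 11000 nM.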

Compound 3, half-maximal inhibitory concentration: 8300 nM
The estimate for compound 3 lay 1.8-fold (0.27 log units) below the measured number; low and high end bracket the measured number.
By their numbers in this assay, from the lowest: compounds 2, 1 and 3 (each within the scatter of the next, the first and the last beyond it).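

In this assay, within the data shown here, the step of fluoro in place of chloro on an aromatic carbon, a 2.2-fold higher number from compound 2 to compound 3 (0.35 log units; beyond the scatter), is the first to pass beyond the scatter, though only modestly, so the identity of the halogen in the 4-halophenyl group registers in this read-out. Among these compounds, the other new step, a 1.3-fold higher number from compound 1 to compound 3 (0.11 log units; within the scatter), stays within the scatter, so 4-fluorophenyl and 2-chlorophenyl on a carbonyl carbon cannot be ordered, and compound 2 and compound 3 are the only pair the numbers separate. Nothing available on these compounds accounts for the separation between compound 2 and compound 3.

Among the compounds shown here, with only two halogens in the 4-position pattern, the single separated pair gives no trend, and an unsubstituted phenyl, a 4-methoxyphenyl or a 4-aminophenyl on the same carbonyl carbon would show whether either halogen matters relative to other groups. Also open, on these data alone, is what 2-fluorophenyl gives, which would show whether the exchange of chlorine for fluorine carries the same size of step in the 2-substituted arrangement.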